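The source may report more compounds than this note shows. Statements on the series, on what has been measured and on what is new or still open speak of the compounds shown alone.

Three measured compounds share one core and differ in the aromatic group attached to it. Compound 1 `COc1ccc(OC)c(-c2nc(C(c3ccccc3)c3ccccc3)sc2CC(=O)O)c1` gives 80% in an in vitro functional assay on HEK285-7 cells for antagonist activity at prostaglandin D2 receptor 2 (Homo sapiens), read by BRET and beta-arrestin recruitment; a higher number here means a larger maximal response, a lower number a smaller maximal response. Compound 2 `NS(=O)(=O)c1ccc(-c2nc(C(c3ccc(F)cc3)c3ccc(F)cc3)sc2CC(=O)O)cc1` gives 80% in this assay, and compound 3 `O=C(O)Cc1sc(C(c2ccccc2)c2ccc(Cl)cc2)nc1-c1ccc(F)cc1` gives 80% there as well. Compound 2 thus stands level with compound 1 and with compound 3 at the digits shown, and both gaps lie within the usual scatter of such measurements.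

Compound 4 `O=C(O)Cc1sc(C(c2ccc(F)cc2)c2ccc(F)cc2)nc1-c1ccnc(Cl)c1` has not yet been measured. It differs from compound 2 in one place: 2-chloropyridin-4-yl in place of 4-sulfamoylphenyl on an aromatic carbon. Among the compounds with values here, no step between measured compounds that differ in a single place is available. Still, compound 1 and compound 3 carry other aromatic groups at the same position of the core and sit at the same level as compound 2, so the maximal response appears insensitive to what occupies this place. The expected step of no change at the digits printed from compound 2 to compound 4 (within the scatter) is therefore none beyond the scatter. Compound 4 is expected to give 80% in this assay, with a range from 66% to 92%.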

Compound 4, largest response reached (reported as efficacy), in percent of the reference or control that the assay uses: 80%
Beside the measured number, compound 4's estimate shows no gap at the digits printed; the measured number falls inside the stated range.
By their numbers in this assay, from the lowest: compounds 1, 2, 3 and 4 (each within the scatter of the next).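

In this assay, within the data shown here, placing 2-chloropyridin-4-yl where 4-sulfamoylphenyl stood gives no change at the digits printed from compound 2 to compound 4 (within the scatter) as the one comparison at this position with everything else in the molecule held fixed. Compound 1 and compound 3 also differ from compound 2 in the large group, so their matching values could not be tied to this position alone. This exchange removes the hydrogen-bond donor and brings a hetero atom into the ring, yet the maximal response holds, though no measurement here explains why.

From the compounds shown here alone, whether a saturated ring such as morpholine, a primary amine or a carboxylic acid at this position would keep the response remains open. With all the compounds shown at one level, nothing yet indicates which group at this position, if any, would shift it.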